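Rigid bicyclic sulfone series: moving the sulfonyl onto a phenoxy

This account rests on a few compounds, and the source may have more. Where it says the series, first, only, none or still open, it means among the compounds named here.

Measured so far, each in a functional assay on the whole organism (strain ICR) for inhibition, with Mus musculus as the target, with a stated time of 16 h, at a dose of 10 mg/kg by the oral route; a lower number here means less inhibition, a higher number more inhibition at the dose given (going by the name of the read-out):
compound 1 `Cn1c(-c2ccccc2C(F)(F)F)nnc1C12CCC(CCS(C)(=O)=O)(CC1)CC2`: 63%
compound 2 `Cn1c(-c2ccccc2C(F)(F)F)nnc1C12CCC(CCS(=O)(=O)C(C)(C)C)(CC1)CC2`: 10%
compound 3 `CC(C)S(=O)(=O)CCC12CCC(c3nnc(-c4ccccc4C(F)(F)F)n3C)(CC1)CC2`: 59%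

Compound 3 stands second highest of the three numbers. Its nearest neighbour is compound 1, a number 4 percentage points lower from compound 1 to compound 3 (within the scatter); its furthest is compound 2, a number 49 percentage points higher from compound 2 to compound 3 (beyond the scatter). Going by the values given here, the only large step seen, a number 53 percentage points lower from compound 1 to compound 2 (beyond the scatter), concerns the group on the sulfonyl sulfur alone.

Compound 4 `Cn1c(-c2ccccc2C(F)(F)F)nnc1C12CCC(COc3ccc(S(C)(=O)=O)cc3)(CC1)CC2` differs from compound 3 as follows: 4-(methylsulfonyl)phenoxy in place of (isopropylsulfonyl)methyl on a saturated chain carbon bound to a saturated ring carbon. Among the compounds with values here, no measured step alters this part of the molecule; all three change only the alkyl on the sulfonyl sulfur or the chain beside it. Compound 4 carries the methyl sulfonyl of compound 1, whose 63% sets the reference. The step of a number 4 percentage points lower from compound 3 to compound 4 (within the scatter) is therefore expected to stay within the scatter, given the uncertainty of an unprecedented change. Compound 4 is estimated at 55%, between 25% and 80%.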

Compound 4, a percentage reported as inhibition, in the whole organism at one dose (the size of the read-out at that dose, not a potency): 28%
Estimate against measurement, compound 4: 27 percentage points above; the range from low to high includes it.
By their numbers in this assay, from the lowest: compound 2; then compound 4; then compounds 3 and 1 (each within the scatter of the next).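

In this assay the place on a saturated chain carbon bound to a saturated ring carbon proves sensitive: 4-(methylsulfonyl)phenoxy gives a number 35 percentage points lower from compound 1 to compound 4 (beyond the scatter) and a number 31 percentage points lower from compound 3 to compound 4 (beyond the scatter) but also a number 18 percentage points higher from compound 2 to compound 4 (beyond the scatter) in the comparison with the tert-butyl sulfone. A methyl on the sulfonyl sulfur therefore does not by itself preserve the read-out of compound 1 once the sulfonyl sits on the phenoxy. No measurement available here accounts for these steps.

Still open, going by these compounds, is whether the phenoxy oxygen, the aromatic ring or the new sulfonyl location drives the loss. Also open, on these data alone, is whether an amine or a carboxylic acid in place of the methylsulfonyl on the phenoxy would change the read-out.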